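Fluoro added to the anilino ring of compound 3

This account rests on a few compounds, and the source may have more. Where it says the series, first, only, none or still open, it means among the compounds named here.

Measured so far:
- compound 1, `Fc1ccc(Nc2[nH]cnc3ncnc2-3)cc1`: 18%
- compound 2, `Fc1ccc(Oc2[nH]cnc3ncnc2-3)cc1`: 0%
- compound 3, `Cn1cnc2c(Nc3ccccc3)ncnc21`: 0%

In an assay on isolated protein for inhibition of RAC-alpha serine/threonine-protein kinase (Homo sapiens), tested at 30 uM (a lower number here means less inhibition, a higher number more inhibition at the concentration tested (going by the name of the read-out)), compound 1 gives 18%, compound 2 gives 0% and compound 3 gives 0%. Compound 3 stands level with compound 2 at the digits printed; the two together are the lowest of the three numbers, and the reading of compound 1 lies higher than that of compound 3 by a margin beyond the scatter. Compound 1 and compound 3 differ in more than one place, so nothing is said here about which of those differences carries the gap.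

Compound 4, `Cn1cnc2c(Nc3ccc(F)cc3)ncnc21`, is the next compound to be run in this assay. It differs from compound 3 as follows: fluoro in place of hydrogen on an aromatic carbon. Among the measured compounds shown here, nothing among the measured compounds isolates this single change, so the step can only be guessed. Given that compound 3 gives 0%, the step from compound 3 to compound 4 is expected to be a number 5 percentage points higher from compound 3 to compound 4 (within the scatter), which is to say no movement beyond the scatter. Compound 4 is therefore expected to read 5%, in a range from 0% to 20%.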

Compound 4, a percentage reported as inhibition, at one concentration (the size of the read-out at that concentration, not a potency): 0%
Estimate against measurement, compound 4: 5 percentage points above, within the range that was stated.
By their numbers in this assay, from the lowest: compounds 2, 3 and 4 (each within the scatter of the next); then compound 1.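

In this assay, among the compounds shown here, the step of fluoro in place of hydrogen on an aromatic carbon, para to a large group, is no change at the digits printed from compound 3 to compound 4 (within the scatter) and is the first single-place comparison. On this core and at this place, fluoro alone therefore gives no reading beyond the scatter, and since neither compound shows measurable inhibition, the step could not have shown any loss. No measured information on the compounds bears on why the reading stays put.

From the compounds shown here alone, whether a larger group at the same place, such as chloro, methoxy or an amine, would lift the reading remains open. So does the effect of fluoro at other places on this ring, and the compounds shown give no potency for any member of the series.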